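Swapping a phenyl ether for a propyl ether in an H1 blocker

This account rests on a few compounds, and the source may have more. Where it says the series, first, only, none or still open, it means among the compounds named here.

Measured so far:
compound 1, `CCCCOCCn1c(N2CCCN(C)CC2)nc2ccccc21`, 10 nM
compound 2, `CN1CCN(c2nc3ccccc3n2CCOc2ccccc2)CC1`, 6.9 nM

Both compounds were tested in a functional assay on ileum for inhibition of histamine H1 receptor (Cavia porcellus); on this read-out higher numbers stand for weaker inhibition and lower numbers for stronger inhibition. Compound 2 has the lowest of the two numbers, and its nearest neighbour is compound 1, which lies within the scatter of repeated measurements, so the two cannot be told apart on these data.

Compound 3, `CCCOCCn1c(N2CCN(C)CC2)nc2ccccc21`, has not yet been measured. It differs from compound 2 in one place: propyl in place of phenyl on an oxygen on a saturated carbon. Going by the values given here, no measured pair shows this change on its own, so its size can only be guessed. Compound 1, which also carries an alkyl ether chain, gives 10 nM in this assay, so a shift beyond the scatter seems unlikely. The step from compound 2 to compound 3 is therefore expected to be small, a 1.4-fold higher number from compound 2 to compound 3 (0.16 log units; within the scatter). Compound 3 is estimated at 10 nM, with a range from 4 nM to 25 nM.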

Compound 3, half-maximal inhibitory concentration: 20 nM
For compound 3 the middle estimate is 2.0-fold (0.30 log units) below the measured one; the measured number falls inside the stated range.
By their numbers in this assay, from the lowest: compounds 2, 1 and 3 (each within the scatter of the next, the first and the last beyond it).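

Going by these compounds alone, putting propyl in place of phenyl on the ether oxygen gives a 2.9-fold higher number from compound 2 to compound 3 (0.46 log units; beyond the scatter) in this assay and is the first change here to step beyond the usual scatter. The group on this oxygen therefore affects inhibition, and phenyl gives the stronger result of this pair, although the step is only modest. Both compounds still inhibit the receptor, so this position accepts a chain without an aromatic ring as well as phenyl, at a modest cost.

This single step cannot separate the loss of the aromatic ring from the drop from 6 heavy atoms to 3, and a cyclohexyl or benzyl group on the same oxygen would be needed to tell these apart. What lies behind the step also stays unexplained, with no supporting measurement available here.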